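Swapping (3-fluorophenyl)carbamoyl for acetamido on the shared core

This account rests on a few compounds, and the source may have more. Where it says the series, first, only, none or still open, it means among the compounds named here.

In a physicochemical assay for lipophilicity, at pH 7.4 (a lower number here means a more polar compound, a higher number a more lipophilic compound), compound 1 `Cc1cc(C(=O)Nc2cccc(F)c2)nn1Cc1cc(Cl)ccc1OCc1ccccc1` gives 2.8 as its reading. Compound 3 `Cc1cc(C(=O)NN2CCOCC2)nn1Cc1cc(Cl)ccc1OCC(C)C` gives 3.1 and so sits within the scatter of compound 1. Compound 2 `Cc1cc(C(=O)NN2CCCCC2)nn1Cc1cc(Cl)ccc1OCC(C)C` gives 3.3 and lies beyond the scatter, on the higher side of compound 1. Compound 4 `CC(=O)Nc1cc(C)n(Cc2cc(Cl)ccc2OCc2ccccc2)n1` has yet to be measured in this assay and departs from compound 1 in one place. The difference acetamido in place of (3-fluorophenyl)carbamoyl on an aromatic carbon amounts to acetamido in place of (3-fluorophenyl)carbamoyl on an aromatic carbon. Within the data shown here, the only measured step between compounds that differ in one place is a number 0.20 log units lower from compound 2 to compound 3 (within the scatter) with morpholin-4-yl in place of piperidin-1-yl on an amide-type nitrogen. That step concerns another place and removes no ring, so it is a weak guide here. Among the measured compounds shown here, the change to compound 4 takes away a six-membered aromatic ring of carbon only, and no measured step does that. A modest fall is therefore expected, resting on the structural change alone. The expected step is a number 0.40 log units lower from compound 1 to compound 4 (beyond the scatter) as a rough estimate with wide margins. For this assay compound 4 is estimated at 2.4 within a range of 1.9 to 2.9 as the expected span.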

Compound 4, distribution coefficient: > 3.7
Compound 4: a limit, no number; the forecaster's own chance of this, stated with the estimate: 3%; at least 1.30 log units between middle value and limit.
By their numbers in this assay, from the lowest: compounds 1, 3 and 2 (each within the scatter of the next, the first and the last beyond it). At a limit, above all of these: compound 4.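

In this assay compound 4 gives > 3.7, which is a limit of the assay and not a number: the limit of > 3.7 in this assay, at which 1 of the 4 values shown sits. At this place, on an aromatic carbon of a five-membered aromatic ring with 2 nitrogen, acetamido in place of (3-fluorophenyl)carbamoyl gives a number at least 0.90 log units higher from compound 1 to compound 4 (beyond the scatter), so the reading rises even though the change takes away a six-membered aromatic ring of carbon only. Among these compounds, the earlier compounds could not show this, as their one step, a number 0.20 log units lower from compound 2 to compound 3 (within the scatter), concerns another place and removes no ring, whereas this change at this position moves the reading by more than the scatter.

Going by these compounds, the true reading of compound 4 stays open, and the step can therefore be given only as a minimum, with its full size unknown. Also open is whether an amine, a carboxylic acid or a longer chain on this same aromatic carbon would read higher than compound 1, as compound 4 does, since acetamido is the only replacement for (3-fluorophenyl)carbamoyl shown here.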